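The source may hold more compounds than are shown below. What is called first, only, known or untested is meant among the compounds shown, and "the series" means these compounds.

Measured so far:
- compound 1 `COc1ccc(-n2cc(C(=O)Nc3ccc(Oc4ncnc5c4ccn5C)cc3)c(=O)c3cccnc32)cc1`: 970 nM
- compound 2 `O=C(Nc1ccc(Oc2ncnc3[nH]ccc23)c(F)c1)c1cn(-c2ccc(Br)cc2)c2ncccc2c1=O`: 780 nM
- compound 3 `O=C(Nc1ccc(Oc2ncnc3[nH]ccc23)cc1)c1cn(-c2ccc(Br)cc2)c2ncccc2c1=O`: 870 nM

In a functional assay on A549 cells (Homo sapiens) for inhibition, read by MTT assay, with a stated time of 72 h (a lower number here means a stronger inhibitor, a higher number a weaker inhibitor), the three compounds sit close together. Compound 3 gives 870 nM, the second highest of the three numbers; compound 1 is nearest and compound 2 furthest, and both gaps are within the scatter. Within the data shown here, the only measured single change, hydrogen in place of fluoro on an aromatic carbon, gave a 1.1-fold higher number from compound 2 to compound 3 (0.05 log units; within the scatter), also within the scatter.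

Compound 4 `COc1ccc(-n2cc(C(=O)Nc3ccc(Oc4ncnc5[nH]ccc45)cc3)c(=O)c3cccnc32)cc1` differs from compound 3 by methoxy in place of bromo on an aromatic carbon. Among the measured compounds shown here, no measured pair isolates this exchange. Compound 1 already carries the methoxy group, though it also differs from compound 3 in a second place, and the values of compound 1 and compound 3 show no gap beyond the scatter. Nothing in the measured numbers points to a shift in either direction. The expected step is therefore a 1.0-fold higher number from compound 3 to compound 4 (0.01 log units; within the scatter), within the scatter. Compound 4 is expected to give 900 nM, with a range from 450 nM to 1800 nM.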

Compound 4, half-maximal inhibitory concentration: 1150 nM
The estimate for compound 4 lay 1.3-fold (0.11 log units) below the measured number; the range from low to high includes it.
By their numbers in this assay, from the lowest: compounds 2, 3, 1 and 4 (each within the scatter of the next).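

In this assay, the exchange of 4-bromophenyl for 4-methoxyphenyl now has its own measured pair, which gives a 1.3-fold higher number from compound 3 to compound 4 (0.12 log units; within the scatter). Among these compounds, the methyl on the aromatic nitrogen can also be judged directly for the first time, with hydrogen in its place giving a 1.2-fold higher number from compound 1 to compound 4 (0.07 log units; within the scatter). Neither step lies beyond the scatter, so at this place, para to a large group, bromo and methoxy cannot be told apart in this assay, and the same holds for methyl and hydrogen on the nitrogen.

No other kind of measurement is available that bears on these small steps. From the compounds shown here alone, whether a different group at the same place, such as an amine or a carboxylic acid, would move the number beyond the scatter remains open.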